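The source may report more compounds than this note shows. Statements on the series, on what has been measured and on what is new or still open speak of the compounds shown alone.

Compound 1 `COc1ccc2occ(CSC(=S)N3CCOCC3)c(=O)c2c1`, compound 2 `COc1ccc2occ(CSC(=S)N3CCCC3)c(=O)c2c1` and compound 3 `O=c1c(Cl)c(CSC(=S)N2CCCC2)oc2ccccc12` were examined in a functional assay on LM7 cells (Homo sapiens) for antiproliferative activity, read by MTT assay, with a stated time of 72 h; on this read-out lower numbers stand for stronger inhibition and higher numbers for weaker inhibition. Compound 2 gives 6000 nM in this assay. For compound 1, this assay reports only > 40000 nM, a limit of the assay rather than a number; this is the limit of > 40000 nM in this assay, at which 1 of the 3 values shown sits. The change that separates the two, (morpholin-4-yl in place of pyrrolidin-1-yl on a thiocarbonyl carbon), thus brought an at least 6.6-fold higher number from compound 2 to compound 1 (0.82 log units; beyond the scatter). Compound 3 gives 1900 nM in this assay, the lowest of the two numbers reported, and the difference between its core and that of compound 2 is not broken down here.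

Compound 4 `O=c1c(Cl)c(CSC(=S)N2CCOCC2)oc2ccccc12` has not yet been measured. For the measured compounds named here, it differs from compound 3 by morpholin-4-yl in place of pyrrolidin-1-yl on a thiocarbonyl carbon, the same change, at the same place on the same kind of carbon, as the one from compound 2 to compound 1. Because that earlier change brought an at least 6.6-fold higher number from compound 2 to compound 1 (0.82 log units; beyond the scatter), compound 4 is expected to show a 7.9-fold higher number from compound 3 to compound 4 (0.90 log units; beyond the scatter), with the size uncertain since the earlier endpoint was only a limit. Compound 4 is therefore estimated at about 15000 nM in this assay, most likely between 5000 nM and 40000 nM.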

Compound 4, half-maximal inhibitory concentration: 19200 nM
Estimate against measurement, compound 4: 1.3-fold (0.11 log units) below; the range from low to high includes it.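

In this assay, morpholin-4-yl in place of pyrrolidin-1-yl on a thiocarbonyl carbon brought a 10-fold higher number from compound 3 to compound 4 (1.00 log units; beyond the scatter), so on the core of compound 3 the change moves the number in the same direction as on the core of compound 2. These two cores show that the direction carries over, but they do not establish that the size does: the same change on two cores in this assay, an at least 6.6-fold higher number (0.82 log units; beyond the scatter) from compound 2 to compound 1 and a 10-fold higher number (1.00 log units; beyond the scatter) from compound 3 to compound 4; the limit leaves it open whether they differ

For compound 1, > 40000 nM is a limit of the assay and not a number.

The compounds shown leave open how other amines on the thiocarbonyl carbon, such as piperidin-1-yl, piperazin-1-yl or an open-chain dimethylamino group, would behave on either core, and whether the same direction would hold for them. Also open, on these data alone, is what each separate difference between the two cores contributes, for instance with a bromine or a methyl group in place of the chlorine of compound 3.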